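The source may hold more compounds than are shown below. What is called first, only, known or untested is meant among the compounds shown, and "the series" means these compounds.

compound 1 `Cn1cc(-c2cnc3[nH]cc(-c4cnn(Cc5ccccc5)c4)c3c2)cn1` gives 3000 nM
compound 2 `Cn1cc(-c2cnc3[nH]cc(-c4cnn(Cc5ccc(F)cc5)c4)c3c2)cn1` gives 1780 nM
compound 3 `Cn1cc(-c2cnc3[nH]cc(-c4cnn(Cc5cccc(C(=O)O)c5)c4)c3c2)cn1` gives > 10000 nM as a limit

All three were tested in a functional assay on KARPAS-299 cells (Homo sapiens) for cytotoxicity, read by XTT assay, with a stated time of 72 h (a lower number here means a stronger inhibitor, a higher number a weaker inhibitor), and share one core. Compound 3 has only a limit and no measured number, and that is the limit of > 10000 nM in this assay, at which 1 of the 3 values shown sits, here.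

Compound 4 `Cn1cc(-c2cnc3[nH]cc(-c4cnn(Cc5ccc(F)c(F)c5)c4)c3c2)cn1` differs from compound 3 by 3,4-difluorophenyl in place of 3-carboxyphenyl on a saturated chain carbon bound to an aromatic nitrogen, with 3,4-difluorophenyl in place of 3-carboxyphenyl on a saturated chain carbon bound to an aromatic nitrogen. Going by the values given here, three measured steps bear on this change. Carboxy in place of hydrogen gave an at least 3.3-fold higher number from compound 1 to compound 3 (0.52 log units; beyond the scatter), and the exchange of 4-fluorophenyl for 3-carboxyphenyl gave an at least 5.6-fold higher number from compound 2 to compound 3 (0.74 log units; beyond the scatter). Both lie beyond the scatter. Fluoro in place of hydrogen gave a 1.7-fold lower number from compound 1 to compound 2 (0.23 log units; within the scatter), which lies within it.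

A lower number is therefore expected in this assay, at least modest in size, with compound 4 expected to land near compound 2 at 1780 nM in this reading. The expected change is an at least 5.5-fold lower number from compound 3 to compound 4 (0.74 log units; beyond the scatter) in all. For compound 4 the estimate is 1800 nM, with an expected range from 700 nM to 4500 nM.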

Compound 4, half-maximal inhibitory concentration: 2260 nM
Estimate against measurement, compound 4: 1.3-fold (0.10 log units) below; measured number inside the range.
By their numbers in this assay, from the lowest: compounds 2, 4 and 1 (each within the scatter of the next). At a limit, above all of these: compound 3.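

At this place, on a saturated chain carbon bound to an aromatic nitrogen, 3,4-difluorophenyl cannot be told apart from phenyl (a 1.3-fold lower number from compound 1 to compound 4 (0.12 log units; within the scatter)) or from 4-fluorophenyl (a 1.3-fold higher number from compound 2 to compound 4 (0.10 log units; within the scatter)) in this assay, so a second fluoro leaves the number within the scatter. The change away from 3-carboxyphenyl is at least modest (an at least 4.4-fold lower number from compound 3 to compound 4 (0.64 log units; beyond the scatter)), and among the four groups shown only 3-carboxyphenyl stands apart from the others. That step rests on a limit and not on a number for compound 3: the limit of > 10000 nM in this assay, at which 1 of the 4 values shown sits.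

The compounds shown leave open whether an amine or a primary amide in place of the carboxylic acid would stay at such a limit or fall among the other three. They also leave open how a longer chain in place of the benzyl link would read in this series.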